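The source may hold more compounds than are shown below. What is called first, only, known or untested is meant among the compounds shown, and "the series" means these compounds.

In a functional assay on the whole organism (strain Wistar) for inhibition, with Rattus norvegicus as the target, read by paw edema, with stated times of 30 min and 0.5 h, at a dose of 20 mg/kg (on this read-out lower numbers stand for less inhibition and higher numbers for more inhibition at the one dose given (going by the name of the read-out)), compound 1 `CCOC(=O)C1=C(C)NC(C)=C(C(=O)OCC)C1c1ccc(OCC(=O)Nc2nc3ccccc3s2)cc1` gives 47.7%, compound 2 `CCOC(=O)C1=C(C)NC(C)=C(C(=O)OCC)C1c1ccc(OCC(=O)NNC(=O)c2ccc(C)cc2)cc1` gives 16.7% and compound 3 `CCOC(=O)C1=C(C)NC(C)=C(C(=O)OCC)C1c1ccc(OCC(=O)NNC(=O)CCC(=O)O)cc1` gives 34.9%. Compound 3 stands second of the three numbers: a number 12.8 percentage points lower from compound 1 to compound 3 (beyond the scatter) and a number 18.2 percentage points higher from compound 2 to compound 3 (beyond the scatter). Compound 4 `CCOC(=O)C1=C(C)NC(C)=C(C(=O)OCC)C1c1ccc(OCC(=O)NN2C(=O)c3ccccc3C2=O)cc1` is not yet measured; it differs from compound 3 by a group of 11 heavy atoms (8 carbon, 1 nitrogen, 2 oxygen; one five-membered non-aromatic ring with 1 hetero atom, one six-membered aromatic ring of carbon only) in place of a group of 8 heavy atoms (4 carbon, 1 nitrogen, 3 oxygen; no ring), on an amide-type nitrogen. Two measured steps exchange the group on the same amide-type nitrogen: a number 31 percentage points lower from compound 1 to compound 2 (beyond the scatter) and a number 12.8 percentage points lower from compound 1 to compound 3 (beyond the scatter), so exchanges at this site have moved the read-out by modest to large amounts, and the direction has depended on the group. For the measured compounds named here, no measured step brings in the group that enters here. A small step, near the scatter, is expected, a number 4.9 percentage points lower from compound 3 to compound 4 (within the scatter). For compound 4 the estimate is 30%, with a range from 12% to 50%.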

Compound 4, a percentage reported as inhibition, in the whole organism at one dose (the size of the read-out at that dose, not a potency): 34.1%
Compound 4: the middle estimate sits 4.1 percentage points below what was measured; measured number inside the range.
By their numbers in this assay, from the lowest: compound 2; then compounds 4 and 3 (each within the scatter of the next); then compound 1.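

In this assay, the group with a five-membered non-aromatic ring and a six-membered aromatic ring of carbon only replaces ((2-carboxyethyl)carbonyl)amino on the amide-type nitrogen, and hydrogen-bond donors in the group fall from 2 to 0, yet the read-out holds level: a number 0.8 percentage points lower from compound 3 to compound 4 (within the scatter). A six-membered aromatic ring of carbon only does not fix the level at this site, with a number 17.4 percentage points higher from compound 2 to compound 4 (beyond the scatter) and a number 13.6 percentage points lower from compound 1 to compound 4 (beyond the scatter). No measurement at hand explains these steps.

Open, going by these compounds, is whether a simple amine or a longer chain ending in a carboxylic acid on this nitrogen would bring the read-out nearer to that of compound 1.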